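The compounds below may be only part of what the source reports. "The series", "measured", "known", "first", "only" and "open" are said of these compounds alone.

Measured compounds:
compound 1 `COc1cc(NC(C)CCCNC(=O)Nc2cccc(Cl)c2)c2ncccc2c1`, 21000 nM in a functional assay on MIA PaCa-2 cells (Homo sapiens) for inhibition, read by MTT assay, with a stated time of 72 h; on this read-out higher numbers stand for weaker inhibition and lower numbers for stronger inhibition
compound 2 `COc1cc(NC(C)CCCNC(=O)Nc2ccc(Br)cc2)c2ncccc2c1`, 23000 nM in this assay

In this assay compound 2 gives the higher of the two numbers, with compound 1 nearest; the step of a 1.1-fold higher number from compound 1 to compound 2 (0.04 log units; within the scatter) is within the scatter, so neither is set apart. Compound 3 `COc1cc(NC(C)CCCNC(=O)NNC(=O)Nc2ccc(Br)cc2)c2ncccc2c1` differs from compound 2 by ((4-bromophenyl)carbamoyl)amino in place of 4-bromophenyl on an amide-type nitrogen. Among the compounds with values here, the single measured step concerns the aryl group only and does not touch this change; no step here informs it. Compound 3 is therefore expected near compound 2, with no step beyond the scatter, a 1.1-fold higher number from compound 2 to compound 3 (0.04 log units; within the scatter). The estimate for compound 3 in this assay is 25000 nM, range 8000 nM to 80000 nM.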

Compound 3, half-maximal inhibitory concentration: 231000 nM
Estimate against measurement, compound 3: 9.2-fold (0.97 log units) below; measured number above the stated range.
By their numbers in this assay, from the lowest: compounds 1 and 2 (each within the scatter of the next); then compound 3.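

In this assay, the substituent on the amide-type nitrogen now proves able to shift the number: ((4-bromophenyl)carbamoyl)amino in place of 4-bromophenyl gives a 10-fold higher number from compound 2 to compound 3 (1.00 log units; beyond the scatter), and in place of 3-chlorophenyl gives an 11-fold higher number from compound 1 to compound 3 (1.04 log units; beyond the scatter). The earlier aryl swap stayed within the scatter and showed no such shift. Nothing available explains this rise. Still open, from the compounds shown here alone, is whether a smaller insert on that nitrogen, such as a single methylene or a plain amino group, gives a similar step, and whether 3-chlorophenyl at the end of the longer group gives the same number as 4-bromophenyl.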